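A few compounds are considered here, and "the series" means these few. Any claim that something is new, unique, unknown or untested is made for them only; others in the source may bear on it.

Measured so far:
- compound 1 `C=C[C@@](C)(/C=C/c1ccc(Nc2ccc(OC)c(OC)c2)cc1)CCC=C(C)C` — in a functional assay on HepG2 cells (Homo sapiens) for cytotoxicity, with a stated time of 72 h (on this read-out lower numbers stand for an effect already at smaller amounts and higher numbers for an effect only at larger amounts of compound), compound 1 gives > 52000 nM, a limit of the assay.
- compound 2 `C=C[C@@](C)(/C=C/c1ccc(Nc2ccc(OC)c(F)c2)cc1)CCC=C(C)C` — in this assay compound 2 gives > 52000 nM, also a limit of the assay.

Compound 2 thus stands at the limit, with no number of its own. Within the data shown here, the only measured step, a step that the two limits leave unreadable from compound 1 to compound 2, cannot be sized because of the limit of > 52000 nM in this assay, at which 2 of the 2 values shown sit. Compound 3 `C=C[C@@](C)(/C=C/c1ccc(Nc2cc(F)c(F)cc2F)cc1)CCC=C(C)C` differs from compound 2 by 2,4,5-trifluorophenyl in place of 3-fluoro-4-methoxyphenyl on a nitrogen on an aromatic ring. Among the measured compounds shown here, no measured step reads on such a change, so compound 3 is expected to stay at the limit, a step that the limit leaves unreadable from compound 2 to compound 3 of none beyond the scatter. For compound 3 the estimate is 60000 nM, within 25000 nM to 200000 nM.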

Compound 3, half-maximal effective concentration: > 52000 nM
Compound 3: only a limit was reported; the forecaster's own chance of this, stated with the estimate: 80%; the middle value lies beyond the limit too.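

In this assay no new step can be read between compound 2 and compound 3, because both stand at a limit of the assay: the limit of > 52000 nM in this assay, at which 3 of the 3 values shown sit. The compounds shown leave open whether the group on the nitrogen changes this read-out at all.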